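Series notes: the step from compound 2 to compound 4

The source may report more compounds than this note shows. Statements on the series, on what has been measured and on what is new or still open speak of the compounds shown alone.

Measured so far in a functional assay on HPAC cells (Homo sapiens) for inhibition, read by MTT assay, with a stated time of 72 h; on this read-out lower numbers stand for stronger inhibition of growth and higher numbers for weaker inhibition of growth:
- compound 1, `O=S(=O)(NCCNCc1ccc(-c2ccccc2)cc1)c1cc(C(F)(F)F)cc(C(F)(F)F)c1`: 2800 nM
- compound 2, `COc1ccc(CNCCCNS(=O)(=O)c2cc(C(F)(F)F)cc(C(F)(F)F)c2)cc1OC`: 3500 nM
- compound 3, `CN(CCCNS(=O)(=O)c1cc(C(F)(F)F)cc(C(F)(F)F)c1)Cc1ccccc1`: 30000 nM

Compound 2 holds the second highest of the three numbers in this assay. Its nearest neighbour is compound 1, whose number lies within the usual scatter of compound 2, so the two cannot be ranked against each other. Compound 3 stands furthest away, with a number well beyond the scatter, the weakest inhibition of growth in the set.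

Compound 4, `O=S(=O)(NCCCNCc1cccc2ccccc12)c1cc(C(F)(F)F)cc(C(F)(F)F)c1`, is not yet measured. It differs from compound 2 in one place: naphthalen-1-yl in place of 3,4-dimethoxyphenyl on a saturated chain carbon bound to an amine nitrogen. No measured pair in the set shares this difference, so no step size can be taken from the data; the expectation rests only on the three numbers shown.

Compound 1 and compound 2 carry different groups at this position and give numbers within the scatter of each other, which suggests that this position tolerates exchange. Compound 4 is therefore expected to land near compound 2, with a step of a 1.3-fold lower number from compound 2 to compound 4 (0.10 log units; within the scatter), which is none beyond the scatter. The estimate for compound 4 in this assay is 2800 nM, within 1000 nM to 8000 nM. Compound 3 shows that a change in this region can shift the number strongly, so the range is kept wide.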

Compound 4, concentration for 50% growth inhibition: 2400 nM
The estimate for compound 4 lay 1.2-fold (0.07 log units) above the measured number; measured number inside the range.
By their numbers in this assay, from the lowest: compounds 4, 1 and 2 (each within the scatter of the next); then compound 3.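

In this assay, going by these compounds alone, naphthalen-1-yl in place of 3,4-dimethoxyphenyl on a saturated chain carbon bound to an amine nitrogen gives a 1.5-fold lower number from compound 2 to compound 4 (0.16 log units; within the scatter), the first step with a single difference, so the two compounds cannot be ranked. The group that leaves carries 2 hydrogen-bond acceptors and the group that enters carries 0, with a second six-membered aromatic ring in their place, and for this pair neither exchange moves the number beyond the scatter. No evidence on the reason for this result is available.

As far as these compounds go, whether this tolerance extends to a group with a carboxylic acid or an amine at this place remains open. The compounds shown also contain no single-difference pair that isolates the methyl on the amine nitrogen of compound 3.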